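The compounds below may be only part of what the source reports. "The series", "measured", "known", "first", "only" and "open" are said of these compounds alone.

The measured compounds and their values in an ADME assay on HFF cells (Homo sapiens) for cytotoxicity, read by MTT assay, with a stated time of 72 h; a higher number here means a weaker inhibitor, a lower number a stronger inhibitor:

Compound 1, `O=C1O/C(=C\Cn2cc(-c3cc(F)cc(F)c3)nn2)C(OCc2ccccc2)=C1OCc1ccccc1`: compound 1 reaches only a limit, > 100000 nM.
Compound 2, `Cc1ccc(-c2cn(C/C=C3\OC(=O)C(OCc4ccccc4)=C3OCc3ccccc3)nn2)cc1`: compound 2 likewise reaches only a limit, > 100000 nM.
Compound 3, `COc1ccc(-c2cn(C[C@H](O)[C@H]3OC(=O)C(OCc4ccccc4)=C3OCc3ccccc3)nn2)cc1`: compound 3 sits at a limit at the other end, < 10 nM.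

Compound 2 therefore stands at the upper edge of what this assay reports: its value is a limit, not a number, and it shares that position with compound 1, as the limit of > 100000 nM in this assay, at which 2 of the 3 values shown sit, shows. Among the measured compounds shown here, the one measured step between neighbours, a step that the two limits leave unreadable from compound 1 to compound 2, cannot be read in size, since both ends are limits. For the measured compounds named here, compound 3 differs from compound 2 in the linker as well as in the aryl substituent, so no single step is drawn to it; it stands at the limit of < 10 nM in this assay, at which 1 of the 3 values shown sits.

The unmeasured compound 4 is `CCCCCc1ccc(-c2cn(C/C=C3\OC(=O)C(OCc4ccccc4)=C3OCc3ccccc3)nn2)cc1`. It differs from compound 2 by butyl in place of hydrogen on a saturated chain carbon bound to an aromatic carbon. Going by the values given here, no measured step changes the aryl substituent by a chain extension of this kind, and the only measured step, a step that the two limits leave unreadable from compound 1 to compound 2, gives no readable size. With compound 2 at a limit, compound 4 is expected to remain at or near that limit, so the step of a number no higher from compound 2 to compound 4 (the limit leaves the size open) is expected to be none beyond the scatter. Compound 4 is estimated at 100000 nM, within 20000 nM to 300000 nM.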

Compound 4, half-maximal inhibitory concentration: > 100000 nM
Compound 4: only a limit was reported; the forecaster's own chance of this, stated with the estimate: 70%; the middle value sits exactly at the limit.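

In this assay compound 4 gives only a limit, > 100000 nM. Compound 1, compound 2 and compound 4 all stand at limits, so the steps among them cannot be read in size. The compounds shown leave open whether the 3,5-difluorophenyl, 4-methylphenyl and 4-pentylphenyl groups differ at all in this assay.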